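The compounds below may be only part of what the source reports. "The series", "measured", "known", "first", "only" and "open" are said of these compounds alone.

Measured so far in this series:
compound 1 `O=C(Nc1ccc(Cl)cc1)c1cc(Oc2ccc(/C=C/c3ccccn3)cc2)ccn1` — 16200 nM
compound 2 `O=C(NCc1ccc(F)cc1)c1cc(Oc2ccc(/C=C/c3ccccn3)cc2)ccn1` — reported only as a limit, > 100000 nM
compound 3 `CC(C)NC(=O)c1cc(Oc2ccc(/C=C/c3ccccn3)cc2)ccn1` — 21400 nM

All three were read in a functional assay on A549 cells (Homo sapiens) for antiproliferative activity, read by CCK-8 assay, with a stated time of 48 h; a higher number here means a weaker inhibitor, a lower number a stronger inhibitor. Compound 3 gives 21400 nM, the higher of the two numbers, but the step of a 1.3-fold higher number from compound 1 to compound 3 (0.12 log units; within the scatter) lies within the scatter, so no order between them is claimed. Compound 2 stands apart: its value is a limit of the assay (the limit of > 100000 nM in this assay, at which 1 of the 3 values shown sits), and the steps of an at least 6.1-fold higher number from compound 1 to compound 2 (0.79 log units; beyond the scatter) and an at least 4.6-fold lower number from compound 2 to compound 3 (0.66 log units; beyond the scatter) are both beyond the scatter.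

Compound 4 `O=C(c1cc(Oc2ccc(/C=C/c3ccccn3)cc2)ccn1)N1CCCC1` is not yet measured. The change from compound 3 is pyrrolidin-1-yl in place of isopropylamino on a carbonyl carbon. The three measured steps all swap the group on the amide-type nitrogen while keeping the amide hydrogen; none removes it, so none bears directly on this change. The near-equal numbers of compound 1 and compound 3 suggest tolerance to the size of the amide substituent, with compound 2 the exception. The step of a 1.4-fold higher number from compound 3 to compound 4 (0.15 log units; within the scatter) is therefore expected to stay within the scatter. Compound 4 is estimated at 30000 nM, in the range 10000 nM to 100000 nM.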

Compound 4, half-maximal inhibitory concentration: 15600 nM
The estimate for compound 4 lay 1.9-fold (0.28 log units) above the measured number; the range from low to high includes it.
By their numbers in this assay, from the lowest: compounds 4, 1 and 3 (each within the scatter of the next). At a limit, above all of these: compound 2.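

In this assay, replacing an amide that keeps its hydrogen with pyrrolidin-1-yl on the carbonyl carbon gives no difference beyond the scatter, whether the group leaving is isopropylamino (a 1.4-fold lower number from compound 3 to compound 4 (0.14 log units; within the scatter)) or (4-chlorophenyl)amino (a 1.0-fold lower number from compound 1 to compound 4 (0.02 log units; within the scatter)), so among compounds 1, 3 and 4 the amide hydrogen is not required for the activity read here. Compound 2 alone goes against this tolerance, and the new compound separates from it as well (an at least 6.4-fold lower number from compound 2 to compound 4 (0.80 log units; beyond the scatter)). The value of compound 2 is a limit, not a number: the limit of > 100000 nM in this assay, at which 1 of the 4 values shown sits.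

From the compounds shown here alone, whether the tolerance extends to piperidin-1-yl, morpholin-4-yl or dimethylamino on the same carbonyl carbon stays open. Also open, going by these compounds, is whether the gap at compound 2 belongs to the benzyl chain as such, which unsubstituted benzylamino or 2-phenylethylamino would test.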